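This account rests on a few compounds, and the source may have more. Where it says the series, first, only, none or still open, it means among the compounds named here.

Measured so far in a functional assay on HT-29 cells (Homo sapiens) for cytotoxicity, read by sulforhodamine B assay; a higher number here means a weaker inhibitor, a lower number a stronger inhibitor:
compound 1 `C=C1[C@@H](OC(C)=O)C[C@@H]2[C@](C)(CO[Si](C)(C)C(C)(C)C)[C@H](OC(C)=O)CC[C@@]2(C)[C@@H]1C[C@@H](Nc1ccc(OC)cc1)C1=CCOC1=O`, giving 5370 nM
compound 2 `C=C1[C@@H](OC(C)=O)C[C@@H]2[C@](C)(CO[Si](C)(C)C(C)(C)C)[C@H](OC(C)=O)CC[C@@]2(C)[C@@H]1C[C@@H](Nc1cccc(F)c1)C1=CCOC1=O`, giving 4520 nM

Compound 2 stands at the lower of the two numbers in this assay, but the gap between the two is a 1.2-fold lower number from compound 1 to compound 2 (0.07 log units; within the scatter), so the two compounds are not separated. Compound 3 `C=C1[C@@H](OC(C)=O)C[C@@H]2[C@](C)(CO[Si](C)(C)C(C)(C)C)[C@H](OC(C)=O)CC[C@@]2(C)[C@@H]1C[C@@H](Nc1ccccc1C(=O)O)C1=CCOC1=O` is the next member of the series. Its change from compound 2 is 2-carboxyphenyl in place of 3-fluorophenyl on an amine nitrogen. Among the compounds with values here, the only measured step, a 1.2-fold lower number from compound 1 to compound 2 (0.07 log units; within the scatter), also exchanged one aryl substituent for another on the same amine nitrogen and did not move the number beyond the scatter; it is the sole comparison bearing on the present change and gives no direction. Within the data shown here, the group that enters differs in kind from anything in the measured pair, so no step covers it directly. Compound 3 is therefore expected to give roughly 6500 nM in this assay, with an estimated range of 2500 nM to 17000 nM. The expected step is a 1.4-fold higher number from compound 2 to compound 3 (0.16 log units; within the scatter), with wide uncertainty.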

Compound 3, half-maximal inhibitory concentration: 5340 nM
Estimate against measurement, compound 3: 1.2-fold (0.09 log units) above; low and high end bracket the measured number.
By their numbers in this assay, from the lowest: compounds 2, 3 and 1 (each within the scatter of the next).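

In this assay, within the data shown here, a carboxylic acid on the aryl ring brings no separation from the earlier compounds: 2-carboxyphenyl in place of 3-fluorophenyl gives a 1.2-fold higher number from compound 2 to compound 3 (0.07 log units; within the scatter), and 2-carboxyphenyl in place of 4-methoxyphenyl gives a 1.0-fold lower number from compound 1 to compound 3 (0.00 log units; within the scatter). The three aryl groups on this amine nitrogen therefore cannot be told apart in this assay, although the entering group adds a hydrogen-bond donor that 3-fluorophenyl lacks. Nothing available explains why these substituents leave the number unresolved.

The compounds shown all carry an aryl group on this nitrogen, so it remains open whether the same holds for a benzyl group or a plain alkyl chain there. Going by these compounds, they also share the rest of the core, so whether a free hydroxyl in place of the silyl ether would change the number remains open too.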